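Swapping the ring oxygen for sulfur beside the oxazolone core

The source may report more compounds than this note shows. Statements on the series, on what has been measured and on what is new or still open speak of the compounds shown alone.

Among the measured compounds shown here, compound 2 `Cc1c(C2CCOCC2)c(=O)on1C(=O)N1CCCCC1` gives 71 nM in an assay (strain Wistar) for inhibition of Hormone-sensitive lipase (Rattus norvegicus), read by spectrophotometry (a lower number here means a stronger inhibitor, a higher number a weaker inhibitor), the higher of the two numbers known, with compound 1 `Cc1c(C(C)(C)C)c(=O)on1C(=O)N1CCCCC1` at 14 nM in this assay. For the measured compounds named here, the one measured step, a 5.1-fold higher number from compound 1 to compound 2 (0.71 log units; beyond the scatter), describes a different exchange and offers only a loose guide. Compound 3 `Cc1c(C2CCSCC2)c(=O)on1C(=O)N1CCCCC1` is the untested compound, carrying (thian-4-yl in place of oxan-4-yl on an aromatic carbon). Going by the values given here, with no step of this kind known, the expected change is small, possibly a modest return toward compound 1, so the estimate is a 1.8-fold lower number from compound 2 to compound 3 (0.25 log units; within the scatter). Compound 3 is expected to give 40 nM in this assay, within 12 nM to 150 nM.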

Compound 3, half-maximal inhibitory concentration: 11 nM
The estimate for compound 3 lay 3.6-fold (0.56 log units) above the measured number; measured number outside the range, below it.
By their numbers in this assay, from the lowest: compounds 3 and 1 (each within the scatter of the next); then compound 2.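

In this assay, exchanging only the ring oxygen for sulfur at this aromatic carbon gives a 6.5-fold lower number from compound 2 to compound 3 (0.81 log units; beyond the scatter), so the weaker result for oxan-4-yl does not extend to thian-4-yl, its sulfur counterpart. Thian-4-yl and tert-butyl cannot be told apart here, with a 1.3-fold lower number from compound 1 to compound 3 (0.10 log units; within the scatter), so this ring can stand in for the branched group at this position. Nothing available explains the difference between sulfur and oxygen.

From the compounds shown here alone, whether a sulfone or a piperidin-4-yl ring, with its amine nitrogen, would behave like thian-4-yl or like oxan-4-yl on this carbon remains open.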